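The compounds below may be only part of what the source reports. "The series", "measured", "known", "first", "only" and "open" are said of these compounds alone.

Measured compounds in hand:
compound 1 `COc1ccc(/C=C/C2CC(=O)C=CO2)cc1OC` — 134 uM
compound 2 `COc1cc(/C=C/C2CC(=O)C=CO2)cc(OC)c1OC` — 155 uM
compound 3 `COc1ccc(/C=C/c2cc(=O)cco2)cc1` — 710 uM

In an ADME assay on HaCaT cells (Homo sapiens) for inhibition, read by sulforhodamine B assay, with a stated time of 48 h (a lower number here means a stronger inhibitor of growth, a higher number a weaker inhibitor of growth), compound 1 gives 134 uM and compound 2 gives 155 uM. The change between them is methoxy in place of hydrogen on an aromatic carbon and the step it made is a 1.2-fold higher number from compound 1 to compound 2 (0.06 log units; within the scatter). Compound 3 stands apart: in this assay compound 3 gives 710 uM, beyond the scatter from both compound 2 and compound 1. The difference between the core of compound 1 and the core of compound 3 is not broken down here.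

Compound 4 `COc1ccc(/C=C/c2cc(=O)cco2)cc1OC` is not yet measured. It differs from compound 3 by methoxy in place of hydrogen on an aromatic carbon. This is the same kind of change as that from compound 1 to compound 2, not the same: in compound 1 the site is also meta to a methoxy group, which it is not in compound 3. On the strength of a 1.2-fold higher number from compound 1 to compound 2 (0.06 log units; within the scatter) the step is expected to be small, a 1.1-fold higher number from compound 3 to compound 4 (0.04 log units; within the scatter), though it has been seen only once and on a different core. Compound 4 is expected to give 780 uM in this assay, within 350 uM to 1700 uM, because compound 3 gives 710 uM.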

Compound 4, concentration for growth inhibition (reported as GI): 690 uM
Compound 4: middle estimate off by 1.1-fold (0.05 log units), on the high side; the measured number falls inside the stated range.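

In this assay, methoxy in place of hydrogen on an aromatic carbon gives a 1.0-fold lower number from compound 3 to compound 4 (0.01 log units; within the scatter), so on the core of compound 3 this change, ortho to a methoxy group, leaves no reading beyond the scatter. Set beside the earlier step, the two cores agree: the same change on two cores in this assay, a 1.2-fold higher number (0.06 log units; within the scatter) from compound 1 to compound 2 and a 1.0-fold lower number (0.01 log units; within the scatter) from compound 3 to compound 4, 1.2-fold (0.08 log units) apart, within the scatter of two such steps This shows that, across these two pairs, the change carries from one core to the other as a step within the scatter, but it does not show that the same would hold on a further core, at another site on the aromatic ring or in an assay of a different kind.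

Compound 1 gives 134 uM and compound 4 gives 690 uM with the same aromatic substitution, and what in the two cores lies behind those printed values stays open. The compounds shown carry only methoxy groups on the aromatic ring, so the effect of an amine, a carboxylic acid or a longer chain there also remains open.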